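From Butyl to Phenyl in a Small Chain Series

A few compounds are considered here, and "the series" means these few. Any claim that something is new, unique, unknown or untested is made for them only; others in the source may bear on it.

In a functional assay on the whole organism for inhibition, with Rattus norvegicus as the target (on this read-out higher numbers stand for an effect only at larger amounts of compound and lower numbers for an effect already at smaller amounts), compound 1 (`CCc1ccc(CC(C)(Oc2ccc(C(C)C)cc2)C(=O)O)cc1`), with an ethyl group, gives 0.1 mg/kg. Compound 2 (`CCCc1ccc(CC(C)(Oc2ccc(C(C)C)cc2)C(=O)O)cc1`), with a propyl group, gives 0.5 mg/kg. Compound 3 (`CCCCc1ccc(CC(C)(Oc2ccc(C(C)C)cc2)C(=O)O)cc1`), with a butyl group, gives 1 mg/kg. Two steps place compound 3 within this set: a 10-fold higher number from compound 1 to compound 3 (1.00 log units; beyond the scatter) is a real separation, whereas a 2.0-fold higher number from compound 2 to compound 3 (0.30 log units; within the scatter) cannot be told apart from repeat noise.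

Compound 4 (`CC(C)c1ccc(OC(C)(Cc2ccc(-c3ccccc3)cc2)C(=O)O)cc1`) keeps the shared core but has phenyl in place of butyl on an aromatic carbon, para to a large group: phenyl in place of butyl on an aromatic carbon.

The closest evidence comes from the chain steps. Along with the step to compound 3, a 5.0-fold higher number from compound 1 to compound 2 (0.70 log units; beyond the scatter) shows that moving on from ethyl raised the number by a modest amount, while the last lengthening stayed within the scatter. None of these steps swaps a chain for a ring, so they guide the expectation only loosely. A small drift towards a higher number is therefore expected, but nothing beyond the scatter. The expected change is a 1.5-fold higher number from compound 3 to compound 4 (0.18 log units; within the scatter). For compound 4 the estimated value is 1.5 mg/kg, with an expected range from 0.3 mg/kg to 7 mg/kg.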

Compound 4, dose for half-maximal effect: 1 mg/kg
Beside the measured number, compound 4's estimate is 1.5-fold (0.18 log units) above it, within the range that was stated.
By their numbers in this assay, from the lowest: compound 1; then compounds 2, 3 and 4 (each within the scatter of the next).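

In this assay, the position on an aromatic carbon, para to a large group, takes a ring as readily as a chain: phenyl in place of butyl gives no change at the digits printed from compound 3 to compound 4 (within the scatter), even though the open chain gives way to a six-membered aromatic ring of carbon only. The same swap measured against the shorter chains gives a 2.0-fold higher number from compound 2 to compound 4 (0.30 log units; within the scatter) and a 10-fold higher number from compound 1 to compound 4 (1.00 log units; beyond the scatter), so only the ethyl group of compound 1 stands apart from the other three groups, with a real separation from each. Nothing available here explains why a flat ring and a flexible chain end up with numbers so hard to tell apart.

Going by these compounds, what happens with a longer chain such as pentyl or hexyl, or with an amine or a methoxy group at this same carbon, stays open, so it is unknown whether the numbers stay at this level or move again. Also open, on these data alone, is whether a methyl group, or plain hydrogen, would take the number further in the direction that compound 1 points.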